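A Small Triazole Replaces a Fused Bicyclic Sulfide

The source may report more compounds than this note shows. Statements on the series, on what has been measured and on what is new or still open speak of the compounds shown alone.

Compound 2 `Cn1c(-c2ccc(NC(=O)CSc3nc4ccccc4s3)cc2)nc(-c2ccccc2)c1-c1ccccc1` gives 18 ug/mL in a functional assay on HT-29 cells (Homo sapiens) for cytotoxicity, read by MTT assay, with a stated time of 24 h; on this read-out higher numbers stand for weaker inhibition and lower numbers for stronger inhibition. Within the data shown here, only one other number exists: compound 1 `Cc1ccc2oc(SCC(=O)Nc3ccc(-c4nc(-c5ccccc5)c(-c5ccccc5)n4C)cc3)nc2c1` gives 22.4 ug/mL, and the step of a 1.2-fold lower number from compound 1 to compound 2 (0.09 log units; within the scatter) places the two within the scatter of each other. Compound 3 `Cn1cnnc1SCC(=O)Nc1ccc(-c2nc(-c3ccccc3)c(-c3ccccc3)n2C)cc1` differs from compound 2 by 4-methyl-4H-1,2,4-triazol-3-yl in place of 1,3-benzothiazol-2-yl on a sulfur. Among the measured compounds shown here, the single measured step exchanged one fused two-ring group for another and changed little, so it bears only loosely on a change that removes the six-membered aromatic ring of carbon only. For the measured compounds named here, with no closer precedent, compound 3 is expected to land near compound 2, a 1.4-fold higher number from compound 2 to compound 3 (0.14 log units; within the scatter), at an estimated 25 ug/mL within 10 ug/mL to 60 ug/mL.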

Compound 3, half-maximal inhibitory concentration: 10.7 ug/mL
Beside the measured number, compound 3's estimate is 2.3-fold (0.37 log units) above it; low and high end bracket the measured number.
By their numbers in this assay, from the lowest: compounds 3, 2 and 1 (each within the scatter of the next, the first and the last beyond it).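

In this assay, a single five-membered ring on the sulfur does as well as the fused two-ring groups: there is a 1.7-fold lower number from compound 2 to compound 3 (0.23 log units; within the scatter) and a 2.1-fold lower number from compound 1 to compound 3 (0.32 log units; beyond the scatter) as a modest gain. The six-membered aromatic ring of carbon only is therefore not required for this level of activity in these compounds.

As far as these compounds go, whether an amine or a carboxylic acid in place of the 4-methyl-4H-1,2,4-triazol-3-yl would hold this level remains open. No measurement on hand explains the result.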